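A few compounds are considered here, and "the series" means these few. Any claim that something is new, unique, unknown or untested is made for them only; others in the source may bear on it.

Of the compounds shown here, three have so far been tested in an assay for inhibition of serine/threonine-protein kinase PLK2 (Homo sapiens), read by FRET and Z'-LYTE, with a stated time of 1 h; on this read-out lower numbers stand for stronger inhibition and higher numbers for weaker inhibition. Compound 1 `CCC1C(=O)N(C)c2cnc(Nc3ccc(S(=O)(=O)NCC(C)C)cc3)nc2N1c1ccn(C)n1` gives 311 nM, which is the high end of the three numbers. Compound 3 `CCC1C(=O)N(C)c2cnc(-n3ccc4cc(C(=O)NC)ccc43)nc2N1c1ccn(C)n1` gives 218 nM, a value within the scatter of compound 1, so the two cannot be told apart. Compound 2 `CC[C@@H]1C(=O)N(C)c2cnc(Nc3ccc(S(=O)(=O)NC)cc3)nc2N1C1CCCC1`, which carries a different group on the shared core, gives 3.4 nM, far beyond the scatter from compound 1. Compound 4 `CCCNS(=O)(=O)c1ccc(Nc2ncc3c(n2)N(c2ccn(C)n2)C(CC)C(=O)N3C)cc1` has not yet been measured; it differs from compound 1 by hydrogen in place of methyl on a saturated chain carbon bound to two saturated chain carbons. Going by the values given here, no measured pair shows this change, so the step is expected to be small, likely within the scatter, in either direction. Compound 4 is expected to give 320 nM, with a range from 120 nM to 850 nM. The expected step of a 1.0-fold higher number from compound 1 to compound 4 (0.01 log units; within the scatter) is estimated to be no larger than the usual scatter.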

Compound 4, half-maximal inhibitory concentration: 190 nM
Compound 4: middle estimate off by 1.7-fold (0.23 log units), on the high side; the measured number falls inside the stated range.
By their numbers in this assay, from the lowest: compound 2; then compounds 4, 3 and 1 (each within the scatter of the next).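

In this assay, the change from isobutyl to propyl gives a 1.6-fold lower number from compound 1 to compound 4 (0.21 log units; within the scatter). Going by these compounds alone, this is the first measured pair for hydrogen in place of methyl on a saturated chain carbon bound to two saturated chain carbons, and removing this one carbon does not separate the two compounds. No supporting measurement bears on the reason for this result.

As far as these compounds go, whether a longer chain, such as pentyl, or an amine on this chain would shift the number stays open. Compound 2 differs from compound 1 in more than one place, so these compounds cannot show which change matters for its much lower number.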